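From ethyl to butyl in compound 1

A few compounds are considered here, and "the series" means these few. Any claim that something is new, unique, unknown or untested is made for them only; others in the source may bear on it.

Measured in a functional assay on HT-29 cells (Homo sapiens) for antiproliferative activity, read by sulforhodamine B assay, with a stated time of 48 h; on this read-out higher numbers stand for weaker inhibition and lower numbers for stronger inhibition:
compound 1 `CCN1CCN(c2ccc(S(=O)(=O)Oc3cccc(F)c3)cc2)C1=O`: > 100000 nM (a limit)
compound 2 `CCN1CCN(c2ccc(S(=O)(=O)Oc3cccc(Cl)c3)cc2)C1=O`: 6800 nM
compound 3 `CCN1CCN(c2ccc(S(=O)(=O)Oc3cccc(Br)c3)cc2)C1=O`: 3800 nM

Compound 1 gives only a limit, not a number: > 100000 nM. Compound 4 `CCCCN1CCN(c2ccc(S(=O)(=O)Oc3cccc(F)c3)cc2)C1=O` keeps the core of compound 1 but carries butyl where compound 1 carries ethyl: ethyl in place of hydrogen on a saturated chain carbon, two bonds along the chain from an amide-type nitrogen in a ring. Among the measured compounds shown here, no measured step touches this chain. All of them exchange fluoro, chloro and bromo on an aromatic carbon, so they bear on it only indirectly. Still, they show that one small change can matter here: an at least 14-fold lower number from compound 1 to compound 2 (1.16 log units; beyond the scatter) and an at least 26-fold lower number from compound 1 to compound 3 (1.42 log units; beyond the scatter) are both large, while a 1.8-fold lower number from compound 2 to compound 3 (0.25 log units; within the scatter) stays within the scatter. A lower number is therefore expected in this assay, with an estimated at least 5.0-fold lower number from compound 1 to compound 4 (0.69 log units; beyond the scatter). Compound 4 is estimated at 20000 nM, with an expected range of 4000 nM to 100000 nM.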

Compound 4, half-maximal inhibitory concentration: 76000 nM
For compound 4 the middle estimate is 3.8-fold (0.58 log units) below the measured one; the measured number falls inside the stated range.
By their numbers in this assay, from the lowest: compounds 3 and 2 (each within the scatter of the next); then compound 4. At a limit, above all of these: compound 1.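

Compound 1 carries a limit, not a number: the limit of > 100000 nM in this assay, at which 1 of the 4 values shown sits. In this assay, butyl in place of ethyl gives an at least 1.3-fold lower number from compound 1 to compound 4 (0.11 log units; that floor lies within the scatter), so this step alone does not establish a real gain. Still, compound 4 has a measured number, which shows that the fluoro compound can reach the measurable range through a change on this chain rather than on the aromatic ring.

Going by these compounds, how a propyl chain, a longer chain or a terminal amine would read remains open. So does the effect of butyl with chloro or bromo in place of fluoro.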